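Cytotoxicity of Pentyl and Hexyl Analogues on HEL Cells

This account rests on a few compounds, and the source may have more. Where it says the series, first, only, none or still open, it means among the compounds named here.

Measured compounds:
- compound 1, `CCCCC#Cc1cc2cn(COCCO)c(=O)nc2o1`: > 100000 nM
- compound 2, `CCCCCc1cc2cn(COCCO)c(O)nc-2n1`: > 400000 nM
- compound 3, `CCCCCC#Cc1cc2cn(COCCO)c(=O)nc2o1`: >= 100000 nM

In a functional assay on HEL cells (Homo sapiens), read by microscopy (on this read-out lower numbers stand for higher toxicity in this test and higher numbers for lower toxicity in this test), compound 1 gives a value that is only a limit of the test, > 100000 nM. For compound 2 the value is likewise only a limit, > 400000 nM. For compound 3 too, >= 100000 nM is a limit. The change from compound 1 to compound 3 is methyl in place of hydrogen on a saturated chain carbon, four bonds along the chain from a triple-bonded carbon, and its step, a step that the two limits leave unreadable from compound 1 to compound 3, cannot be read because both values sit at limits (the limit of > 100000 nM in this assay, at which 1 of the 3 values shown sits, (the limit of >= 100000 nM in this assay, at which 1 of the 3 values shown sits)). The cores of compound 1 and compound 2 differ in a way not broken down here.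

Compound 4, `CCCCCCc1cc2cn(COCCO)c(O)nc-2n1`, is the unmeasured partner of compound 2; the change is methyl in place of hydrogen on a saturated chain carbon, five bonds along the chain from an aromatic carbon, the same kind of change as before, though the place reads five bonds from an aromatic carbon rather than four from a triple-bonded one. Since compound 2 is known only at a limit (the limit of > 400000 nM in this assay, at which 1 of the 3 values shown sits), the step from compound 2 to compound 4 is expected to be a number no higher from compound 2 to compound 4 (the limit leaves the size open), with a number seldom reported. Compound 4 is estimated at 400000 nM, between 100000 nM and 1000000 nM.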

Compound 4, minimum cytotoxic concentration: > 400000 nM
Compound 4 ended at the assay's limit (the forecaster's own chance of this, stated with the estimate: 85%); the middle value lies on the limit itself.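

The step between compound 2 and compound 4 cannot be read, as both values are only limits of this assay. The compounds shown leave open whether methyl in place of hydrogen on the chain changes toxicity at all.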